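Replacing a Tetrazole Tail with a Carboxycyclohexyl Group

This account rests on a few compounds, and the source may have more. Where it says the series, first, only, none or still open, it means among the compounds named here.

Three related compounds have been examined in an assay on isolated protein for inhibition of endoplasmic reticulum aminopeptidase 2 (Homo sapiens); a lower number here means a stronger inhibitor, a higher number a weaker inhibitor. Compound 1 `O=C(NC1(C(=O)O)CCCCC1)c1cccc2c(Br)c(-c3ccc(Cl)cc3)oc12` carries a 1-carboxycyclohexyl group on its amide nitrogen. Compound 3 `CC(C)(NC(=O)c1cccc2cc(-c3ccc(Cl)cc3)oc12)C(=O)O` carries a simpler carboxylic acid bearing group in the same position. Compound 2 `CC(C)(NC(=O)c1cc(F)cc2cc(-c3ccc(Cl)cc3)oc12)c1nnn[nH]1` carries a 1-(1H-tetrazol-5-yl)-1-methylethyl group instead, and in this assay compound 2 gives "not determined" (no result reported). In this assay compound 1 gives > 30000 nM, which is a limit of the assay rather than a number. In this assay compound 3 gives > 30000 nM, again a limit rather than a number. Compound 2 therefore stands without a number of its own, alongside (the limit of > 30000 nM in this assay, at which 2 of the 3 values shown sit).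

Compound 4 `O=C(NC1(C(=O)O)CCCCC1)c1cc(F)cc2cc(-c3ccc(Cl)cc3)oc12` is the new compound, differing from compound 2 by 1-carboxycyclohexyl in place of 1-(1H-tetrazol-5-yl)-1-methylethyl on an amide-type nitrogen. Since no measured step connects any two of these compounds, no size of change in this assay can be read off; the expectation is simply that compound 4 sits at the limit, as compound 1 does with > 30000 nM. Compound 4 is therefore expected to give about 30000 nM, within 10000 nM to 100000 nM.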

Compound 4, half-maximal inhibitory concentration: > 30000 nM
Compound 4: a limit, no number; the forecaster's own chance of this, stated with the estimate: 80%; the middle value lies on the limit itself.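

In this assay compound 4 gives > 30000 nM, which is a limit of the assay and not a number. Within the data shown here, compound 2 has no number, and no step to compound 4 can be read. On these data alone, what 1-carboxycyclohexyl in place of 1-(1H-tetrazol-5-yl)-1-methylethyl does to inhibition stays open.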